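Removing the Benzyl Methoxy in a Benzothiazole Cytotoxicity Series

A few compounds are considered here, and "the series" means these few. Any claim that something is new, unique, unknown or untested is made for them only; others in the source may bear on it.

Compound 1, `COc1ccc(CNC(=O)CSc2nc3ccc(NC(=O)c4ccccc4OC)cc3s2)cc1`: 2100 nM
Compound 2, `COc1ccc(CNC(=O)CSc2nc3ccc(NC(=O)c4ccccc4)cc3s2)cc1`: 12700 nM

Of the compounds shown here, two have been measured in a functional assay on HepG2 cells (Homo sapiens) for cytotoxicity, read by MTT assay, with a stated time of 48 h; on this read-out lower numbers stand for stronger inhibition and higher numbers for weaker inhibition. Compound 1 gives the lowest number of the two; compound 2 gives 12700 nM, and the step of a 6.0-fold higher number from compound 1 to compound 2 (0.78 log units; beyond the scatter) is the only measured one, arising from hydrogen in place of methoxy on an aromatic carbon of the benzamide part of the shared core.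

Compound 3, `COc1ccccc1C(=O)Nc1ccc2nc(SCC(=O)NCc3ccccc3)sc2c1`, has not yet been measured. It differs from compound 1 by hydrogen in place of methoxy on an aromatic carbon; the change therefore sits on the benzyl part of the core, not where compound 2 lost its methoxy. Among the compounds with values here, no measured pair covers this exact position. Within the data shown here, the one step that bears on it, from compound 1 to compound 2, shows that taking away a methoxy elsewhere on the core weakened inhibition modestly. By analogy, compound 3 is expected to show a small loss of potency, estimated as a 2.4-fold higher number from compound 1 to compound 3 (0.38 log units; beyond the scatter), but with real uncertainty because the position differs. The estimate for compound 3 in this assay is 5000 nM, with a range from 2000 nM to 15000 nM.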

Compound 3, half-maximal inhibitory concentration: 8000 nM
Beside the measured number, compound 3's estimate is 1.6-fold (0.20 log units) below it; the range from low to high includes it.
By their numbers in this assay, from the lowest: compound 1; then compounds 3 and 2 (each within the scatter of the next).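

In this assay the change from 4-methoxybenzyl to benzyl gives a 3.8-fold higher number from compound 1 to compound 3 (0.58 log units; beyond the scatter) and so is a modest step beyond the scatter, which shows that the methoxy on this ring, para to a large group, has a measurable bearing on the read-out. Within the data shown here, until now the only measured step was the loss of the methoxy on the benzamide part of the shared core, a 6.0-fold higher number from compound 1 to compound 2 (0.78 log units; beyond the scatter) and this result adds that replacing either methoxy of compound 1 with hydrogen moves the number in the same direction. No measured finding is available to explain the step at this position.

The compounds shown leave open how an amine, a hydroxyl group or a longer ethoxy chain in this same place would read in this assay and so whether methoxy itself matters or any group there would serve. They also leave open what would happen with both methoxy groups replaced by hydrogen in one molecule, and whether the two steps would then add up or not.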